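Sulfonate esters on a shared core: amide to urea

The compounds below may be only part of what the source reports. "The series", "measured", "known", "first", "only" and "open" are said of these compounds alone.

Compound 2 `CC(C)c1ccccc1OS(=O)(=O)c1ccc(NC(=O)CCCCl)cc1`: 6200 nM
Compound 1 `CC(C)C(=O)Nc1ccc(S(=O)(=O)Oc2ccccc2C(C)C)cc1`: 14000 nM

In a functional assay on HT-29 cells (Homo sapiens) for antiproliferative activity, read by sulforhodamine B assay, with a stated time of 48 h (on this read-out higher numbers stand for weaker inhibition and lower numbers for stronger inhibition), compound 2 gives the lowest of the two numbers; the nearest, compound 1, gives 14000 nM, a step of a 2.3-fold lower number from compound 1 to compound 2 (0.35 log units; beyond the scatter). Compound 3 `CCCNC(=O)Nc1ccc(S(=O)(=O)Oc2ccccc2C(C)C)cc1` differs from compound 2 by propylamino in place of 3-chloropropyl on a carbonyl carbon. No measured step touches a propylamino group on this carbonyl carbon, so the only step shown, from isopropyl to 3-chloropropyl, gives no direct guide. Compound 3 is therefore expected to stay close to compound 2, a step of a 1.3-fold higher number from compound 2 to compound 3 (0.11 log units; within the scatter). The estimate for compound 3 in this assay is 8000 nM, within 2500 nM to 25000 nM.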

Compound 3, half-maximal inhibitory concentration: 6300 nM
Compound 3: the middle estimate sits 1.3-fold (0.10 log units) above what was measured, and the stated range covers the measured number.
By their numbers in this assay, from the lowest: compounds 2 and 3 (each within the scatter of the next); then compound 1.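

In this assay a nitrogen-linked chain on this carbonyl carbon serves as well as the 3-chloropropyl chain, with propylamino in its place giving (a 1.0-fold higher number from compound 2 to compound 3 (0.01 log units; within the scatter)). Propylamino in place of isopropyl gives (a 2.2-fold lower number from compound 1 to compound 3 (0.35 log units; beyond the scatter)), a modest step of the same reach as that seen with 3-chloropropyl. No measurement here bears on why the two chains read alike.

The compounds shown leave open how a plain propyl group on this carbonyl carbon would read. Going by these compounds, whether butylamino, a longer chain on the nitrogen, or dimethylamino would hold these numbers also remains open.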